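Carboxy for hydroxy on a quinoline-type amide series

This account rests on a few compounds, and the source may have more. Where it says the series, first, only, none or still open, it means among the compounds named here.

Of the compounds shown here, three have been measured so far. Compound 1 `Cc1ccc2nc(C(=O)Nc3c(F)cc(-c4cccc(F)c4)cc3F)c(C)c(O)c2c1` carries a hydroxy group on its core; in a functional assay on Hep 3B2 cells (Homo sapiens) for antiproliferative activity, read by MTT assay, with a stated time of 24 h, tested at 1.23 ug/mL (a lower number here means a weaker effect, a higher number a stronger effect of the compound at the concentration tested), compound 1 gives 11.2%. Compound 3 `Cc1ccc2nc(C(=O)Nc3c(F)cc(-c4cccc(F)c4)cc3F)c(C)c(C(=O)O)c2c1` differs from compound 1 in one place only, (carboxy in place of hydroxy on an aromatic carbon), and in this assay compound 3 gives 21.3%. The step of a number 10.1 percentage points higher from compound 1 to compound 3 (beyond the scatter) is the only one of its kind measured here. Compound 2 `COc1ccc2nc(C(=O)Nc3ccc(-c4ccccc4)cc3)c(C)c(O)c2c1` shares the hydroxy group of compound 1 but has a different core; the difference between the two cores is not broken down here. In this assay compound 2 gives 14.2%, which sits within the scatter of compound 1 and also within the scatter of compound 3.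

Compound 4 `COc1ccc2nc(C(=O)Nc3ccc(-c4ccccc4)cc3)c(C)c(C(=O)O)c2c1` has not yet been measured. It differs from compound 2 by carboxy in place of hydroxy on an aromatic carbon, the same change as that from compound 1 to compound 3, at a place described in the same words. The expectation for compound 4 rests only on the step of a number 10.1 percentage points higher from compound 1 to compound 3 (beyond the scatter) seen once in this series. Carried over to compound 2, the estimated step of a number 9.8 percentage points higher from compound 2 to compound 4 (within the scatter) is of about that size. Among the compounds with values here, compound 4 is therefore expected to give about 24% in this assay, with a plausible range from 12% to 36%, wide because only the single step of a number 10.1 percentage points higher from compound 1 to compound 3 (beyond the scatter) stands behind it.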

Compound 4, a percentage reported as inhibition, at one concentration (the size of the read-out at that concentration, not a potency): 11.3%
Compound 4: the middle estimate sits 12.7 percentage points above what was measured, outside the stated range (below it).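

Carried to the second core, carboxy in place of hydroxy on an aromatic carbon gives a number 2.9 percentage points lower from compound 2 to compound 4 (within the scatter) in this assay, so the step beyond the scatter seen on the first core does not recur as one here. Even so, the two steps cannot be told apart: the same change on two cores in this assay, a number 10.1 percentage points higher (beyond the scatter) from compound 1 to compound 3 and a number 2.9 percentage points lower (within the scatter) from compound 2 to compound 4, 13 percentage points apart, within the scatter of two such steps. Within the data shown here, the series therefore shows neither that this change keeps its size from one core to another nor that the core alters its outcome, since each core supplies only one pair, read at a single concentration.

The compounds shown leave open whether an amine or a methyl ester on the same aromatic carbon would give a read-out different from those of hydroxy and carboxy. They also leave open which of the several differences between the two cores, if any, matters for this change, and whether the change would give a clearer step on a further core or at another concentration in this assay.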